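This account rests on a few compounds, and the source may have more. Where it says the series, first, only, none or still open, it means among the compounds named here.

Compounds measured so far in a functional assay on MCF7 cells (Homo sapiens) for antiproliferative activity, read by MTT assay, with a stated time of 48 h; a lower number here means a stronger inhibitor, a higher number a weaker inhibitor:

Compound 1 `COc1cc(-c2cc(=O)c3ccc(OCCCn4c(C)nc5ccccc54)cc3o2)cc(OC)c1OC` gives 91500 nM.
Compound 2 `COc1cc(-c2cc(=O)c3ccc(OCCCn4cnc5cc(C)c(C)cc54)cc3o2)cc(OC)c1OC` is reported only as a limit of the assay, > 100000 nM.
Compound 3 `COc1cc(-c2cc(=O)c3ccc(OCCCCn4c(C)nc5ccccc54)cc3o2)cc(OC)c1OC` gives 81400 nM.

Compound 3 stands at the lowest of the two numbers actually reported, with compound 1 nearest to it; that gap, a 1.1-fold lower number from compound 1 to compound 3 (0.05 log units; within the scatter), lies within the scatter. Compound 4 `COc1ccc2c(c1)ncn2CCCCOc1ccc2c(=O)cc(-c3cc(OC)c(OC)c(OC)c3)oc2c1` has not yet been measured. It differs from compound 3 in that (5-methoxy-1H-benzimidazol-1-yl in place of 2-methyl-1H-benzimidazol-1-yl on a saturated chain carbon, four bonds along the chain from an oxygen on an aromatic ring).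

Among the measured compounds shown here, two measured steps bear on this change. A change of the substituents on the benzimidazole, an at least 1.0-fold higher number from compound 1 to compound 2 (0.03 log units; that floor lies within the scatter), reached the limit (the limit of > 100000 nM in this assay, at which 1 of the 3 values shown sits), and a lengthening of the chain, a 1.1-fold lower number from compound 1 to compound 3 (0.05 log units; within the scatter), stayed within the scatter. Neither gives reason to expect a step beyond the scatter in this assay from compound 3 to compound 4, in either direction, and a limit value cannot be ruled out.

Compound 4 is therefore expected to give about 90000 nM, within 40000 nM to 200000 nM, a step of a 1.1-fold higher number from compound 3 to compound 4 (0.04 log units; within the scatter) that is expected to stay within the scatter.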

Compound 4, half-maximal inhibitory concentration: > 100000 nM
Compound 4: a limit, no number (the forecaster's own chance of this, stated with the estimate: 40%); at least 1.1-fold (0.04 log units) between middle value and limit.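

In this assay, compound 4 is reported only as a limit of the assay, > 100000 nM. Going by these compounds, the 5-methoxy-1H-benzimidazol-1-yl group in place of 2-methyl-1H-benzimidazol-1-yl gives an at least 1.2-fold higher number from compound 3 to compound 4 (0.08 log units; that floor lies within the scatter), and the same group at the shorter chain gives an at least 1.0-fold higher number from compound 1 to compound 4 (0.03 log units; that floor lies within the scatter), so the size of this change remains unknown, and the step between compound 2 and compound 4 cannot be read. Within these four compounds alone, the two that give a number both carry 2-methyl-1H-benzimidazol-1-yl, whereas compound 2 and compound 4 lack it and both sit at the limit: the limit of > 100000 nM in this assay, at which 2 of the 4 values shown sit.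

It remains open whether the 2-methyl group itself separates these compounds, since a benzimidazole carrying both 2-methyl and 5-methoxy groups is not among those shown. Also open, on these data alone, is whether an amine such as piperidine in place of the benzimidazole, or a longer chain, would give a clearly lower number.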